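Aryl variation on the acetic acid series in this assay

The source may hold more compounds than are shown below. What is called first, only, known or untested is meant among the compounds shown, and "the series" means these compounds.

Compound 3 `Cc1cccc(/C=C2\CN(CC(=O)O)c3c(C)cccc3C2=O)c1` gives 39.1% in an assay on HL-60 cells for inhibition of glutathione S-transferase P (Homo sapiens), read by spectrophotometry, tested at 20 uM; a lower number here means less inhibition, a higher number more inhibition at the concentration tested (going by the name of the read-out). Among the three measured compounds it stands second highest: compound 2 `Cc1cccc2c1N(CC(=O)O)C/C(=C\c1ccccc1Cl)C2=O` gives 51.9%, and compound 1 `Cc1cccc2c1N(CC(=O)O)C/C(=C\c1ccc(F)cc1)C2=O` gives 22.9%, so compound 3 lies between them, with a number 12.8 percentage points lower from compound 2 to compound 3 (beyond the scatter) and a number 16.2 percentage points higher from compound 1 to compound 3 (beyond the scatter) both beyond the scatter.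

Compound 4 `COc1ccc(/C=C2\CN(CC(=O)O)c3c(C)cccc3C2=O)cc1` carries the change (4-methoxyphenyl in place of 3-methylphenyl on a double-bonded chain carbon bound to a double-bonded ring carbon).

For the measured compounds named here, no measured step involves a 4-methoxyphenyl group, so the bearing of the known steps is indirect. The steps that concern the same position are a number 29 percentage points higher from compound 1 to compound 2 (beyond the scatter) and a number 16.2 percentage points higher from compound 1 to compound 3 (beyond the scatter), and both show that moving away from 4-fluorophenyl raised inhibition, while the 2-chlorophenyl compound 2 and the 3-methylphenyl compound 3 differ by a number 12.8 percentage points lower from compound 2 to compound 3 (beyond the scatter). The only other substituent with the substitution pattern of the entering group, the 4-fluorophenyl of compound 1, gave the lowest number of the set. On that basis a modest decrease in this assay is expected for compound 4, of about a number 9.1 percentage points lower from compound 3 to compound 4 (within the scatter).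

The expected value for compound 4 is therefore 30%, with a range of 15% to 48%.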

Compound 4, a percentage reported as inhibition, at one concentration (the size of the read-out at that concentration, not a potency): 31.5%
Compound 4: middle estimate off by 1.5 percentage points, on the low side; the measured number falls inside the stated range.
By their numbers in this assay, from the lowest: compounds 1, 4 and 3 (each within the scatter of the next, the first and the last beyond it); then compound 2.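

In this assay, 4-methoxyphenyl in place of 3-methylphenyl on a double-bonded chain carbon bound to a double-bonded ring carbon gives a number 7.6 percentage points lower from compound 3 to compound 4 (within the scatter) and so cannot be read as a change, and methoxy in place of fluoro on an aromatic carbon, with a number 8.6 percentage points higher from compound 1 to compound 4 (within the scatter) as its step, also stays unresolved. Compound 4 thus sits within the scatter of both compound 1 and compound 3, even though those two stand apart by a number 16.2 percentage points higher from compound 1 to compound 3 (beyond the scatter) and no clean order follows for these three aryl groups. For the compounds shown here, the only step from compound 4 that can be read is a number 20.4 percentage points lower from compound 2 to compound 4 (beyond the scatter) and, with the earlier steps, this leaves the 2-chlorophenyl of compound 2 as the one group of the four whose number lies beyond the scatter of all the others.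

No data on hand bear on the cause of these differences. The compounds shown leave open whether compound 2 owes its number to the chlorine or to the place of the substituent on the ring, which 4-chlorophenyl and 2-methoxyphenyl analogues would separate, and whether the carboxylic acid matters, which a primary amide in its place would test.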